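Ring contraction of the amide substituent on a shared sulfonamide core

The source may report more compounds than this note shows. Statements on the series, on what has been measured and on what is new or still open speak of the compounds shown alone.

The series rests on one shared core, carried by compound 1 `O=C(c1ccccc1)N1CCC(NS(=O)(=O)c2cc(S(=O)(=O)c3ccccc3)ccc2C(F)(F)F)CC1`, compound 2 `O=C(O)CCCC(=O)N1CCC(NS(=O)(=O)c2cc(S(=O)(=O)c3ccccc3)ccc2C(F)(F)F)CC1` and compound 3 `O=C(C1CCNCC1)N1CCC(NS(=O)(=O)c2cc(S(=O)(=O)c3ccccc3)ccc2C(F)(F)F)CC1`, which differ only in the group on the carbonyl carbon. In an assay on U2OS cells for inhibition of secreted frizzled-related protein 1 (Homo sapiens), read by a luciferase reporter, with a stated time of 18 h (on this read-out lower numbers stand for an effect already at smaller amounts and higher numbers for an effect only at larger amounts of compound), compound 1 gives 250 nM and compound 2 gives 570 nM. Compound 3 gives 150 nM in this assay, the lowest of the three numbers; its gap to compound 1 is within the scatter a 1.7-fold lower number from compound 1 to compound 3 (0.22 log units; within the scatter), while the other gap is larger a 3.8-fold lower number from compound 2 to compound 3 (0.58 log units; beyond the scatter). The step to the unmeasured compound 4 `O=C([C@H]1CCNC1)N1CCC(NS(=O)(=O)c2cc(S(=O)(=O)c3ccccc3)ccc2C(F)(F)F)CC1` is pyrrolidin-3-yl in place of piperidin-4-yl on a carbonyl carbon. Going by the values given here, two measured steps bear on it: the one arriving at compound 3 from the phenyl analogue, a 1.7-fold lower number from compound 1 to compound 3 (0.22 log units; within the scatter), and the one from the 3-carboxypropyl analogue, a 3.8-fold lower number from compound 2 to compound 3 (0.58 log units; beyond the scatter). Both end at the piperidin-4-yl group that compound 4 keeps in spirit as a cyclic secondary amine, now as pyrrolidin-3-yl. The account therefore expects no step beyond the scatter in this assay, that is a 1.2-fold higher number from compound 3 to compound 4 (0.08 log units; within the scatter). Compound 4 is estimated at 180 nM in this assay, with a range from 80 nM to 400 nM.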

Compound 4, half-maximal effective concentration: 700 nM
Beside the measured number, compound 4's estimate is 3.9-fold (0.59 log units) below it; the measured number lies above the stated range.
By their numbers in this assay, from the lowest: compounds 3 and 1 (each within the scatter of the next); then compounds 2 and 4 (each within the scatter of the next).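

In this assay, going from the six-membered to the five-membered non-aromatic ring on the carbonyl carbon is not a neutral exchange (a 4.7-fold higher number from compound 3 to compound 4 (0.67 log units; beyond the scatter)), even though the counted hydrogen-bond donor and acceptor stay the same and the ring nitrogen remains. The earlier compounds had shown only changes of the group's type, and this step shows that the exact ring at this position also bears on the number, since the pyrrolidin-3-yl compound also stands apart from the phenyl analogue (a 2.8-fold higher number from compound 1 to compound 4 (0.45 log units; beyond the scatter)) and its number cannot be told from that of the 3-carboxypropyl analogue (a 1.2-fold higher number from compound 2 to compound 4 (0.09 log units; within the scatter)). Nothing available here gives a reason for this step, so the change in ring size, the shift of the attachment point and the defined stereocentre cannot be separated.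

The compounds shown leave open whether the opposite stereo form of the pyrrolidin-3-yl group, or a piperidin-3-yl group, would give a number nearer to that of compound 3 or to that of compound 4. They also leave open how an open-chain amine on the same carbonyl carbon would compare with the two ring amines.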